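An Ethynyl Group Replaces the Branched Alkenyl on the Carbonyl

The source may report more compounds than this note shows. Statements on the series, on what has been measured and on what is new or still open speak of the compounds shown alone.

In a functional assay on HCT-116 cells (Homo sapiens) for inhibition, read by MTT assay, with a stated time of 48 h (a lower number here means a stronger inhibitor, a higher number a weaker inhibitor), compound 1 `COc1ccc(CN(C(C)=O)c2cc(OC)c(OC)c(OC)c2)cc1O` gives 270 nM and compound 2 `COc1ccc(CN(C(=O)C=C(C)C)c2cc(OC)c(OC)c(OC)c2)cc1O` gives 290 nM as its half-maximal inhibitory concentration. The two numbers lie within the scatter of each other, so compound 2 stands level with compound 1 and neither can be ranked. Compound 3 `C#CC(=O)N(Cc1ccc(OC)c(O)c1)c1cc(OC)c(OC)c(OC)c1` keeps the shared core and differs from compound 2 only in the group on a carbonyl carbon, by ethynyl in place of 2-methylprop-1-en-1-yl on a carbonyl carbon in all, with ethynyl in place of 2-methylprop-1-en-1-yl. Going by the values given here, one measured step bears on this change. At the same carbonyl carbon, 2-methylprop-1-en-1-yl in place of methyl gave a 1.1-fold higher number from compound 1 to compound 2 (0.03 log units; within the scatter) and stayed within the scatter. Among the compounds with values here, no measured compound yet carries ethynyl there, so this single pair is thin evidence. From that pair, no step beyond the scatter is expected in this assay in either direction. The estimated step is a 1.1-fold lower number from compound 2 to compound 3 (0.05 log units; within the scatter) and the margin around it is kept wide. For compound 3 the expected value is 260 nM with an estimated range from 100 nM to 700 nM when measured.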

Compound 3, half-maximal inhibitory concentration: 310 nM
Beside the measured number, compound 3's estimate is 1.2-fold (0.08 log units) below it; measured number inside the range.
By their numbers in this assay, from the lowest: compounds 1, 2 and 3 (each within the scatter of the next).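

With ethynyl on the carbonyl carbon, this assay gives a 1.1-fold higher number from compound 2 to compound 3 (0.03 log units; within the scatter), and replacing methyl at the same place gives a 1.1-fold higher number from compound 1 to compound 3 (0.06 log units; within the scatter). Until now, only one replacement at this carbonyl carbon could be read, the change from methyl to 2-methylprop-1-en-1-yl; there are now three groups, and the numbers do not separate any two of them. A group with a triple bond, one with a double bond and methyl thus stand level in this cell assay, a finding that holds for compounds 1, 2 and 3 only, and nothing measured here offers an explanation for it.

The compounds shown leave open whether this level holds for quite different groups on the same carbonyl carbon, such as a phenyl ring, a dimethylamino group or a longer chain like n-hexyl. They also leave open how much the shared core contributes, for its hydroxy and methoxy groups are identical in all three compounds, so a replacement of the hydroxy group by a fluorine atom, for example, would be a separate question.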